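Swapping the aryl group on the alkyne of compound 2

The compounds below may be only part of what the source reports. "The series", "measured", "known", "first", "only" and "open" are said of these compounds alone.

Measured so far:
- compound 1 `Cc1cccc(C#Cc2ccc3c(n2)CCN(C(C)C)C3=O)c1`: 510 nM
- compound 2 `CC(C)N1CCc2nc(C#Cc3cccnc3)ccc2C1=O`: 19600 nM

In an assay on HEK293 cells for displacement of a labelled ligand from metabotropic glutamate receptor 5 (Homo sapiens), with a stated time of 2 h (a higher number here means a weaker inhibitor, a lower number a stronger inhibitor), compound 1 gives 510 nM, while compound 2 gives 19600 nM, the highest number of the two. Going by the values given here, the only step measured between them is a 38-fold higher number from compound 1 to compound 2 (1.58 log units; beyond the scatter), so replacing the 3-methylphenyl ring on the triple-bonded carbon with a pyridin-3-yl ring made the compound much weaker.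

Compound 3 `CC(C)N1CCc2nc(C#Cc3cccs3)ccc2C1=O` has not been measured. It differs from compound 2 by thiophen-2-yl in place of pyridin-3-yl on a triple-bonded carbon. Among the compounds with values here, no measured pair shows the thiophen-2-yl ring directly, so the one step that bears on this change is the large one from compound 1 to compound 2: a six-membered ring with one nitrogen on this position was costly, and returning to a ring without that nitrogen may recover part of what was lost. The expected step is therefore a fall in the number, a 13-fold lower number from compound 2 to compound 3 (1.12 log units; beyond the scatter), in this assay. Compound 3 is estimated at 1500 nM, with a range from 400 nM to 6000 nM.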

Compound 3, inhibition constant: 1930 nM
For compound 3 the middle estimate is 1.3-fold (0.11 log units) below the measured one, and the stated range covers the measured number.
By their numbers in this assay, from the lowest: compound 1; then compound 3; then compound 2.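

In this assay the change to thiophen-2-yl brings a 10-fold lower number from compound 2 to compound 3 (1.01 log units; beyond the scatter) and so shows that a hetero atom in the ring on the triple-bonded carbon does not by itself carry the large cost seen with pyridin-3-yl, since this five-membered aromatic ring with one sulfur recovers much of that loss. The recovery is not complete, as thiophen-2-yl in place of 3-methylphenyl still gives a 3.8-fold higher number from compound 1 to compound 3 (0.58 log units; beyond the scatter) in this assay, a modest step that is beyond the scatter and leaves compound 1 with the lowest number of the three. No measurement shown here explains why these three rings differ.

From the compounds shown here alone, the three rings differ in several ways at once: ring size, the hetero atom and, in compound 1, the methyl group, so the share of each in these steps remains unknown. A plain phenyl ring would test the methyl group alone, while thiophen-3-yl and pyridin-2-yl would show whether moving the sulfur or the nitrogen around the ring changes the number in this assay as well.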